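This account rests on a few compounds, and the source may have more. Where it says the series, first, only, none or still open, it means among the compounds named here.

Working notes on the series. Compound 3 `Cc1cc(O)cc(-c2nn(CC#N)cc2-c2ccnc(-c3ccc(Oc4ccccc4)cc3)c2)c1` stands lowest of the three numbers in a functional assay on NCI-H322M cells (Homo sapiens) for cytotoxicity, read by sulforhodamine B assay, with a stated time of 48 h, tested at 10 uM (on this read-out lower numbers stand for a stronger effect and higher numbers for a weaker effect at the one concentration tested), where compound 3 gives -89%. The nearest number belongs to compound 2 `COc1cc(C)cc(-c2nn(CC#N)cc2-c2ccc(-c3cccc(C(C)=O)c3)nc2)c1`, which in this assay gives -10%, and the furthest to compound 1 `COc1cc(C)cc(-c2c(-c3ccnc(-c4ccc(C(C)=O)cc4)c3)cnn2CC#N)c1`, which in this assay gives 70%; both gaps from compound 3 lie beyond the scatter. Going by the values given here, no step between measured compounds that differ in a single place is available, so the read-across to compound 4 `Cc1cc(O)cc(-c2nn(CC#N)cc2-c2ccnc(-c3ccc(N(C)C)cc3)c2)c1` rests on the structural change alone. Compound 4 differs from compound 3 by dimethylamino in place of phenoxy on an aromatic carbon. Compound 1 and compound 2 carry other groups at several places and give no guide to this particular exchange. Since compound 3 gives -89% in this assay, the change is more likely to move the number upward, toward a weaker effect, than further down, though the size is open. In this assay the expected step is a number 54 percentage points higher from compound 3 to compound 4 (beyond the scatter). For compound 4 the estimate in this assay is -35%, with a range from -85% to 30%.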

Compound 4, a percentage reported as activity, at one concentration (the size of the read-out at that concentration, not a potency): -11%
The estimate for compound 4 lay 24 percentage points below the measured number, within the range that was stated.
By their numbers in this assay, from the lowest: compound 3; then compounds 4 and 2 (each within the scatter of the next); then compound 1.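

Dimethylamino in place of phenoxy on this aromatic carbon, para to a large group, is read directly in this assay and gives a number 78 percentage points higher from compound 3 to compound 4 (beyond the scatter) with the rest of the structure unchanged. The group at this position therefore bears strongly on the read-out at the one concentration tested, which compound 1 and compound 2 could not show, as each differs from compound 3 at several places. Nothing measured on these compounds accounts for the size of the step.

Going by these compounds alone, the exchange removes the aromatic ring and the oxygen together, so the single step does not tell which part matters. Methoxy, benzyloxy or a phenylamino group on the same carbon would leave open whether the effect of phenoxy can be kept with a different link or without the ring.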